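This account rests on a few compounds, and the source may have more. Where it says the series, first, only, none or still open, it means among the compounds named here.

Compound 1 `CCOC(=O)N1N=C(c2ccccc2)CC1c1cc(OC)c(OC)c(OC)c1` gives 6680 nM
Compound 2 `COc1cc(C2CC(c3ccccc3)=NN2C(=O)OCc2ccccc2)cc(OC)c1OC` gives > 10000 nM

Both values come from a functional assay on A549 cells (Homo sapiens) for antiproliferative activity, read by MTT assay, with a stated time of 48 h; a higher number here means a weaker inhibitor of growth, a lower number a stronger inhibitor of growth. Among the compounds with values here, compound 1 holds the only actual number here. The value for compound 2 is a limit of the assay.

Compound 3 `CCOC(=O)N1N=C(c2cccc(O)c2)CC1c1cc(OC)c(OC)c(OC)c1` carries hydroxy in place of hydrogen on an aromatic carbon, meta to a large group, and differs from compound 1 thus: hydroxy in place of hydrogen on an aromatic carbon. Within the data shown here, the sole measured step, an at least 1.4-fold higher number from compound 1 to compound 2 (0.17 log units; that floor lies within the scatter), changes another place, so it does not bear directly on this change. No step beyond the scatter is therefore expected, and its direction is open. The expected step is a 1.3-fold lower number from compound 1 to compound 3 (0.13 log units; within the scatter). For compound 3 the estimated value is 5000 nM, with an expected range from 1500 nM to 10000 nM.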

Compound 3, concentration for 50% growth inhibition: 5120 nM
Estimate against measurement, compound 3: 1.0-fold (0.01 log units) below; low and high end bracket the measured number.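

Placing hydroxy on an aromatic carbon, meta to a large group, gives a 1.3-fold lower number from compound 1 to compound 3 (0.12 log units; within the scatter) in this assay, and this is what the step adds: the change from phenyl to 3-hydroxyphenyl moves the number only within the scatter. Compound 3 also gives an actual number, not a limit. Nothing measured here bears on the reason for this result.

Going by these compounds, whether an amine or a carboxylic acid in the same place would behave alike remains open. So does the effect of hydroxy elsewhere on this ring.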